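This account rests on a few compounds, and the source may have more. Where it says the series, first, only, none or still open, it means among the compounds named here.

Compound 1 `CN1CCN(c2ccc(Nc3ncc4nc(SCc5ccccc5)n(C5CCOCC5)c4n3)cc2)CC1` is tested in a functional assay on HCC827 cells (Homo sapiens) for antiproliferative activity, read by MTT assay, with a stated time of 72 h (a higher number here means a weaker inhibitor, a lower number a stronger inhibitor), and gives 107 nM. Among the three compounds measured so far, compound 1 has the lowest number. Compound 3 `CN(C)CCN(C)c1ccc(Nc2ncc3nc([S+]([O-])c4ccccc4)n(C4CCOCC4)c3n2)cc1` gives 1330 nM in this assay, and compound 2 `CN1CCN(c2ccc(Nc3ncc4nc([S+]([O-])Cc5cccnc5)n(C5CCCC5)c4n3)cc2)CC1` gives 2350 nM; both of these numbers lie well beyond the usual scatter from that of compound 1. Compound 4 `CN1CCN(c2ccc(Nc3ncc4nc([S+]([O-])Cc5ccccc5)n(C5CCOCC5)c4n3)cc2)CC1` has not yet been measured. It differs from compound 1 in one place: a group of 9 heavy atoms (7 carbon, 1 oxygen, 1 sulfur; one six-membered aromatic ring of carbon only) in place of a group of 8 heavy atoms (7 carbon, 1 sulfur; one six-membered aromatic ring of carbon only), on an aromatic carbon. Among the compounds with values here, no single-change step between measured compounds is available, so the size of the step is uncertain, but a loss of potency beyond the scatter is expected, because compound 2 gives 2350 nM and compound 3 gives 1330 nM. For compound 4 the estimate is 600 nM, with a range from 200 nM to 2000 nM. That estimate means a step of a 5.6-fold higher number from compound 1 to compound 4 (0.75 log units; beyond the scatter) is expected.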

Compound 4, half-maximal inhibitory concentration: 433 nM
Compound 4: the middle estimate sits 1.4-fold (0.14 log units) above what was measured; low and high end bracket the measured number.
By their numbers in this assay, from the lowest: compound 1; then compound 4; then compounds 3 and 2 (each within the scatter of the next).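

In this assay, adding one oxygen to the sulfur of the benzylsulfanyl group gives a 4.0-fold higher number from compound 1 to compound 4 (0.61 log units; beyond the scatter). Within the data shown here, the other compounds differ from compound 1 in more than one place, so this pair is the one that isolates the change. It shows that this position, on an aromatic carbon of the five-membered ring, responds to a single added oxygen, though only modestly.

From the compounds shown here alone, a sulfone, with a second oxygen on the sulfur, or an amine in place of the sulfur remains open at this position. Nothing measured here explains why the added oxygen raises the number.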